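Swapping Vinyl for 2-Methylprop-1-en-1-yl on the Carbonyl

The source may report more compounds than this note shows. Statements on the series, on what has been measured and on what is new or still open speak of the compounds shown alone.

Of the compounds shown here, two sharing one core have been measured so far, and a third awaits its number. In a functional assay on MCF7 cells (Homo sapiens) for antiproliferative activity, read by MTT assay, with a stated time of 72 h (on this read-out higher numbers stand for weaker inhibition and lower numbers for stronger inhibition), compound 1 `C=CC(=O)Nc1cccc(Oc2nc(Nc3ccn(C)n3)nc3c2CSCC3)c1` gives > 50000 nM, which is a limit of the assay and not a number. Among the compounds with values here, compound 2 `C=CC(=O)Nc1cccc(Oc2nc(Nc3cccc(C#N)c3)nc3c2CSCC3)c1` gives 21700 nM, the only true number available, so it is the sole numerical reference point for what follows.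

Compound 3 `CC(C)=CC(=O)Nc1cccc(Oc2nc(Nc3cccc(C#N)c3)nc3c2CSCC3)c1` keeps all of compound 2 except for one group: 2-methylprop-1-en-1-yl in place of vinyl on a carbonyl carbon.

Within the data shown here, the only measured step is an at least 2.3-fold lower number from compound 1 to compound 2 (0.36 log units; beyond the scatter). It lies beyond the scatter, but it concerns the group on a nitrogen on an aromatic ring, not the carbonyl carbon. Among the measured compounds shown here, it therefore gives no direct guide to this change, and no measured step does. Any forecast in this assay is uncertain, with a small move towards weaker inhibition expected at most.

The estimated step is a 1.3-fold higher number from compound 2 to compound 3 (0.11 log units; within the scatter). For compound 3 the expected value is 28000 nM, with an estimated range from 12000 nM to 60000 nM.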

Compound 3, half-maximal inhibitory concentration: > 50000 nM
Compound 3: only a limit was reported; the forecaster's own chance of this, stated with the estimate: 25%; middle value at least 1.7-fold (0.25 log units) from the limit.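

Placing 2-methylprop-1-en-1-yl in place of vinyl on the carbonyl carbon gives an at least 2.3-fold higher number from compound 2 to compound 3 (0.36 log units; beyond the scatter), so in this assay this position, which the earlier step left untouched, clearly responds to the group placed on it. Compound 3 gives > 50000 nM, which is a limit of the assay and not a number. The step is therefore a minimum, and its full size cannot be read, because the values at both ends of the series stop at this limit, leaving compound 2 as the only one with a true number: the limit of > 50000 nM in this assay, at which 2 of the 3 values shown sit.

The compounds shown do not reveal whether a prop-1-en-1-yl group, or a vinyl group carrying a dimethylamine, would hold the activity of compound 2 at 21700 nM or lose it as well. They also leave open why the change weakens inhibition, and whether any other group on this carbonyl carbon could bring the number lower than that of compound 2.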